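Methyl-to-nitro swap carried onto the pyrazoline series

The source may report more compounds than this note shows. Statements on the series, on what has been measured and on what is new or still open speak of the compounds shown alone.

Two cores are represented. Compound 1 `Cc1ccc2nc(NC(=O)/C=C/OC3=CC=C3)sc2c1` and compound 2 `O=C(/C=C/OC1=CC=C1)Nc1nc2ccc([N+](=O)[O-])cc2s1` share one of them; compound 3 `CC(=O)N1N=C(Nc2nc3ccc(C)cc3s2)CC1c1ccc(Cl)cc1` and the unmeasured compound 4 `CC(=O)N1N=C(Nc2nc3ccc([N+](=O)[O-])cc3s2)CC1c1ccc(Cl)cc1` share the other. The difference between the two cores is not broken down here.

In a functional assay on the whole organism (Hindlimb, strain albino) with Mus musculus as the target, in the maximal electroshock model, with a stated time of 0.5 h (on this read-out lower numbers stand for an effect already at smaller amounts and higher numbers for an effect only at larger amounts of compound), compound 1 gives 505 umol/kg, and compound 2 gives 597 umol/kg. The change between them, (nitro in place of methyl on an aromatic carbon), produced a 1.2-fold higher number from compound 1 to compound 2 (0.07 log units; within the scatter), so the two values cannot be told apart. Compound 3 gives 25.5 umol/kg in this assay, the lowest of the three numbers and beyond the scatter from both others.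

Compound 4 carries the same change on the second core, (nitro in place of methyl on an aromatic carbon), with the place described in identical words. On the first core the change left the read-out essentially where it was, so a similarly flat step is expected here. The expected step is a 1.2-fold higher number from compound 3 to compound 4 (0.07 log units; within the scatter). Within the data shown here, this rests on the earlier step of a 1.2-fold higher number from compound 1 to compound 2 (0.07 log units; within the scatter) as the only measured precedent. Compound 4 is thus expected to give about 30 umol/kg in this assay, with a plausible range from 13 umol/kg to 75 umol/kg.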

Compound 4, dose for half-maximal effect: 132 umol/kg
Estimate against measurement, compound 4: 4.4-fold (0.64 log units) below, and the stated range ends below it.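

In this assay, nitro in place of methyl on the core of compound 3 gives a 5.2-fold higher number from compound 3 to compound 4 (0.71 log units; beyond the scatter) and so is not a flat step. The change therefore does not carry over at a single size from the core of compound 1 to the core of compound 3, and the two steps differ: the same change on two cores in this assay, a 1.2-fold higher number (0.07 log units; within the scatter) from compound 1 to compound 2 and a 5.2-fold higher number (0.71 log units; beyond the scatter) from compound 3 to compound 4, 4.4-fold (0.64 log units) apart, beyond the scatter of two such steps. This shows that the size of the step depends on the core for these two pairs, but with one pair per core it does not show which part of the core makes the difference, what lies behind it, or how the step would run on any further core.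

Open, on these data alone, is whether the two cores would also part for an amine or a carboxylic acid on the same aromatic carbon, since only methyl and nitro appear there. Also open, as far as these compounds go, is whether an amine would leave the number flat on the core of compound 1 and raise it on the core of compound 3.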